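Bromo to fluoro on the core of compound 1

The source may report more compounds than this note shows. Statements on the series, on what has been measured and on what is new or still open speak of the compounds shown alone.

Measured in a functional assay on KYSE-70 cells for antiproliferative activity against KYSE-70 cell line (Homo sapiens), read by MTT assay, with a stated time of 72 h; a higher number here means a weaker inhibitor, a lower number a stronger inhibitor:
- compound 1 `O=C(Nc1cccc(F)c1)c1cc(=O)[nH]c2cc(Br)ccc12`: 8900 nM
- compound 2 `O=C(Nc1cccc(C(F)(F)F)c1)c1cc(=O)[nH]c2cc(Br)ccc12`: > 20000 nM, a limit
- compound 3 `O=C(Nc1cccc(OC(F)(F)F)c1)c1cc(=O)[nH]c2cc(Br)ccc12`: > 20000 nM, a limit

Within the data shown here, compound 1 is the only compound here with a number, so it has no measured neighbour to be ranked against. The other two compounds stop at the limit of > 20000 nM in this assay, at which 2 of the 3 values shown sit.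

Next comes compound 4 `O=C(Nc1cccc(F)c1)c1cc(=O)[nH]c2cc(F)ccc12`, which differs from compound 1 on the core: fluoro in place of bromo on an aromatic carbon.

Among the measured compounds shown here, no measured step touches the bromo. The two readable steps, an at least 2.2-fold higher number from compound 1 to compound 2 (0.35 log units; beyond the scatter) and an at least 2.2-fold higher number from compound 1 to compound 3 (0.35 log units; beyond the scatter), both replace the fluoro that compound 4 keeps, so they are only a loose guide. They do show that compound 1 can lose activity in this assay through a single substitution, which tilts the expectation slightly towards a higher number. The estimate is a 1.2-fold higher number from compound 1 to compound 4 (0.09 log units; within the scatter), an expected step that stays within the scatter. Compound 4 is expected at 11000 nM, with an estimated range from 4500 nM to 20000 nM.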

Compound 4, half-maximal inhibitory concentration: > 20000 nM
Compound 4 was reported as a limit; the forecaster's own chance of this, stated with the estimate: 25%; middle value at least 1.8-fold (0.25 log units) from the limit.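

Earlier steps changed only the fluoro of compound 1, whereas this one changes the core, and in this assay that change is also a loss: an at least 2.2-fold higher number from compound 1 to compound 4 (0.35 log units; beyond the scatter). The bromo on the core therefore counts for activity in compound 1, and with the fluoro kept, replacing it with fluoro is not tolerated as a neutral swap. Compound 4 gives > 20000 nM, a limit and not a number, so the step has a lower bound only, and most of this small set now sits at that same limit: the limit of > 20000 nM in this assay, at which 3 of the 4 values shown sit.

Steps between compounds at the limit cannot be read, so compound 2 and compound 3 stay unranked. On these data alone, whether chloro, methyl, methoxy or an amine in place of the bromo would match compound 1 or improve on it remains open.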